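This account rests on a few compounds, and the source may have more. Where it says the series, first, only, none or still open, it means among the compounds named here.

Going by the values given here, in a functional assay on the whole organism with Mus musculus as the target, in the rotarod test (a lower number here means that less compound is needed, a higher number that more compound is needed for the effect), compound 2 `CC(=O)NCC(=O)N(C)c1ccc(Cl)cc1C(=O)c1ccccc1Cl` gives 58 mg/kg, the only actual number among the three compounds measured. Compound 3 `CN(C(=O)CNC(=O)CN1CCN(c2ccccc2)CC1)c1ccc(Cl)cc1C(=O)c1ccccc1Cl` gives > 100 mg/kg, which is a limit and not a number. The data thus crowd against (the limit of > 100 mg/kg in this assay, at which 2 of the 3 values shown sit).

Compound 4 `CC(=O)NCC(=O)Nc1ccc(Cl)cc1C(=O)c1ccccc1Cl` has not yet been measured. Its structure departs from that of compound 2 as follows: hydrogen in place of methyl on an amide-type nitrogen. In words, hydrogen stands in place of methyl on an amide-type nitrogen.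

Among the compounds with values here, no measured step changes this place alone. Within the data shown here, the one step available, an at least 1.7-fold higher number from compound 2 to compound 3 (0.23 log units; that floor lies within the scatter), concerns a different part of the molecule and gives only a floor, so it says little about this change. Compound 1 `CC(=O)NCC(=O)Nc1ccc(Cl)cc1C(=O)c1ccccc1` already has hydrogen on that nitrogen, and it gives > 100 mg/kg, which is also a limit and not a number. It differs from compound 4 in a further place as well, so it serves only as a loose guide.

On the reading of compound 1, a small step towards a higher number is expected in this assay, probably not clearly beyond the usual scatter. The expected step is a 1.6-fold higher number from compound 2 to compound 4 (0.19 log units; within the scatter). The estimated value for compound 4 is 90 mg/kg, with an expected range from 40 mg/kg to 200 mg/kg.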

Compound 4, dose for half-maximal effect: > 100 mg/kg
Compound 4 gave a limit, no number; the forecaster's own chance of this, stated with the estimate: 45%; middle value at least 1.1-fold (0.04 log units) from the limit.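

In this assay, hydrogen in place of methyl on the amide-type nitrogen now has a measured step of its own, which compound 1 could not supply: an at least 1.7-fold higher number from compound 2 to compound 4 (0.23 log units; that floor lies within the scatter). Going by these compounds alone, this step is only a floor and it lies within the scatter, so it does not establish a real difference between methyl and hydrogen at this place, although compound 2, with methyl, remains the only compound with an actual number. The step from compound 1 to compound 4, with chloro in place of hydrogen on an aromatic carbon, cannot be read, because both of its ends are limits and the data crowd against the same ceiling: the limit of > 100 mg/kg in this assay, at which 3 of the 4 values shown sit.

The compounds shown leave open whether ethyl or a longer chain on this nitrogen would give a number in this assay and how such a number would stand against that of compound 2. They also leave open whether a small amine such as dimethylamino, in place of the 4-phenylpiperazin-1-yl group of compound 3, would give a number rather than a limit.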